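The source may report more compounds than this note shows. Statements on the series, on what has been measured and on what is new or still open speak of the compounds shown alone.

Three compounds sharing one core were tested, and all three gave only a limit. Compound 1 `O=C1COC(c2ccc(/N=C/c3ccc(Cl)cc3)cc2)=NN1` carries a 4-chlorophenyl on a carbon with a double bond to nitrogen. In an assay on cells for inhibition of Amine oxidase [flavin-containing] A (Homo sapiens), read by Amplex Red, with a stated time of 30 min (a higher number here means a weaker inhibitor, a lower number a stronger inhibitor), compound 1 reaches only a limit of the assay, > 100000 nM. Compound 2 `Cc1cccc(/C=N/c2ccc(C3=NNC(=O)CO3)cc2)c1` differs by 3-methylphenyl in place of 4-chlorophenyl on a carbon with a double bond to nitrogen. In this assay compound 2 likewise stops at a limit, > 100000 nM. That step comes out as a step that the two limits leave unreadable from compound 1 to compound 2. Compound 3 `O=C1COC(c2ccc(/C=C/c3ccc(Cl)cc3)cc2)=NN1` has a core whose difference from the core of compound 1 is not broken down here. In this assay compound 3 also gives only a limit, > 100000 nM. Compound 4 `Cc1cccc(/C=C/c2ccc(C3=NNC(=O)CO3)cc2)c1` carries the same kind of change, (3-methylphenyl in place of 4-chlorophenyl on a double-bonded chain carbon bound to a double-bonded chain carbon), now on a double-bonded chain carbon bound to a double-bonded chain carbon rather than on a carbon with a double bond to nitrogen. Because (the limit of > 100000 nM in this assay, at which 3 of the 3 values shown sit), the expected step is only a step that the limit leaves unreadable from compound 3 to compound 4. Compound 4 is therefore estimated near 200000 nM, between 50000 nM and 1000000 nM.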

Compound 4, half-maximal inhibitory concentration: > 100000 nM
Compound 4 was reported as a limit; the forecaster's own chance of this, stated with the estimate: 85%; the middle value is on the limit's open side.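

Compound 3 and compound 4 both stop at a limit, so the step between them cannot be read: the limit of > 100000 nM in this assay, at which 4 of the 4 values shown sit. The compounds shown leave open whether anything built on this shared core gives a measurable value in this assay.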